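Phenethyl in Place of Fluorophenyl on the Sulfur

The source may hold more compounds than are shown below. What is called first, only, known or untested is meant among the compounds shown, and "the series" means these compounds.

Compound 3 `Nc1ccccc1NC(=O)c1ccc(CSc2ccc(F)cc2)cc1` has the lowest number of the three measured compounds: in a functional assay on A-375 cells (Homo sapiens) for inhibition, read by CCK-8 assay, with a stated time of 72 h, tested at 8 uM (on this read-out lower numbers stand for less inhibition of growth and higher numbers for more inhibition of growth at the one concentration tested), compound 3 gives 54.3%, while compound 2 `Cc1ccc(SCc2ccc(C(=O)Nc3ccccc3N)cc2)cc1` gives 67% and compound 1 `COc1ccc(SCc2ccc(C(=O)Nc3ccccc3N)cc2)cc1` gives 81.8%. The measured gaps are a number 12.7 percentage points lower from compound 2 to compound 3 (beyond the scatter) and a number 27.5 percentage points lower from compound 1 to compound 3 (beyond the scatter). Compound 4 `Nc1ccccc1NC(=O)c1ccc(CSCCc2ccccc2)cc1` alters a different part of the molecule: phenethyl in place of 4-fluorophenyl on a sulfur. Within the data shown here, no measured step touches the sulfur; each of them, including a number 14.8 percentage points lower from compound 1 to compound 2 (beyond the scatter), swaps one group for another on an aromatic carbon, so nothing here tells how exchanging the whole group on the sulfur for a phenethyl chain will behave. The expectation is therefore a number close to that of compound 3, with wide uncertainty. Compound 4 is expected to give 55%, between 30% and 78%, an estimated step of a number 0.7 percentage points higher from compound 3 to compound 4 (within the scatter).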

Compound 4, percent growth inhibition at one concentration: 69.9%
Compound 4: the middle estimate sits 14.9 percentage points below what was measured; measured number inside the range.
By their numbers in this assay, from the lowest: compound 3; then compounds 2 and 4 (each within the scatter of the next); then compound 1.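

Swapping the whole group on the sulfur for phenethyl does not lower the reading uniformly in this assay; the outcome depends on which group leaves. Replacing 4-fluorophenyl gives a number 15.6 percentage points higher from compound 3 to compound 4 (beyond the scatter), and replacing 4-methylphenyl gives a number 2.9 percentage points higher from compound 2 to compound 4 (within the scatter). Replacing 4-methoxyphenyl, however, gives a number 11.9 percentage points lower from compound 1 to compound 4 (beyond the scatter), so a ring held further from the sulfur keeps much of the growth inhibition without matching the best reading here.

Still open, from the compounds shown here alone, is how a shorter benzyl group, a longer phenylpropyl chain or a chain ending in an amine would behave on the sulfur. Nothing available explains these steps.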